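Chloro removal on the quinazolinyl oxygen of compound 1

This account rests on a few compounds, and the source may have more. Where it says the series, first, only, none or still open, it means among the compounds named here.

Compound 1 `Clc1ccc(COc2ccccc2/C=C/C(/C=C/c2ccccn2)=N/Oc2ncnc3cc(Cl)ccc23)c(Cl)c1` is measured in a functional assay on SMMC-7721 cells (Homo sapiens) for inhibition, read by MTT assay, with a stated time of 72 h (on this read-out lower numbers stand for stronger inhibition and higher numbers for weaker inhibition), and gives 10400 nM, the highest of the three numbers in the series. Compound 2 `Clc1ccc(COc2ccc(/C=C/C(/C=C/c3ccccn3)=N/Oc3ncnc4cc(Cl)ccc34)cc2)cc1` gives 630 nM and compound 3 `Cc1cccc(COc2ccc(/C=C/C(/C=C/c3ccccn3)=N/Oc3ncnc4ccccc34)cc2)c1` gives 640 nM; both lie well beyond the scatter below compound 1, and the two of them are within the scatter of each other. Compounds 2 and 3 differ from compound 1 in several places at once, so no single change can be read from them.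

Compound 4 `Clc1ccc(COc2ccccc2/C=C/C(/C=C/c2ccccn2)=N/Oc2ncnc3ccccc23)c(Cl)c1` is not yet measured. It differs from compound 1 in one place: hydrogen in place of chloro on an aromatic carbon of the shared core. Among the compounds with values here, no measured pair isolates this change. The expectation is a step from compound 1 to compound 4 of a 1.2-fold lower number from compound 1 to compound 4 (0.06 log units; within the scatter), not beyond the scatter in either direction. Compound 4 is therefore estimated at 9000 nM in this assay, with a range from 3500 nM to 25000 nM.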

Compound 4, half-maximal inhibitory concentration: 8550 nM
The estimate for compound 4 lay 1.1-fold (0.02 log units) above the measured number, and the stated range covers the measured number.
By their numbers in this assay, from the lowest: compounds 2 and 3 (each within the scatter of the next); then compounds 4 and 1 (each within the scatter of the next).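

Within the data shown here, the pair isolates this position for the first time: in this assay, the change from 7-chloroquinazolin-4-yl to quinazolin-4-yl gives a 1.2-fold lower number from compound 1 to compound 4 (0.09 log units; within the scatter), a step within the scatter. In the setting of compound 1, the chloro on the aromatic carbon of the shared core can therefore be exchanged for hydrogen without a readable change in this read-out. No supporting evidence bears on why this exchange leaves the number within the scatter.

As far as these compounds go, whether the same exchange gives so small a step in the setting of compound 2, which also carries this chloro, stays open. Also open, from the compounds shown here alone, is whether a methoxy group, an amine or a carboxylic acid at this place would give a step beyond the scatter.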